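This account rests on a few compounds, and the source may have more. Where it says the series, first, only, none or still open, it means among the compounds named here.

Compound 2 `Cc1c(OCCCCOc2ccc(C(=O)O)cc2)ccc(C(=O)CC2CCCC2)c1C` gives 16.2% in an assay on HEK293 cells for positive allosteric modulation of metabotropic glutamate receptor 2 (Rattus norvegicus), read by thallium flux, with a stated time of 2.5 min; on this read-out higher numbers stand for larger maximal responses and lower numbers for smaller maximal responses. Compound 3 `Cc1c(OCCCCOc2ccc(C(=O)O)cc2)ccc(C(=O)CC(C)C)c1C` gives 19%, and the step of a number 2.8 percentage points higher from compound 2 to compound 3 (within the scatter), so compound 2 and compound 3 sit together at the low end. Within the data shown here, compound 1 `Cc1c(OCCCCOc2ccc(C(=O)O)cc2)ccc(C(=O)CC2CCCC2)c1O` gives 82.6%, and the step of a number 66.4 percentage points lower from compound 1 to compound 2 (beyond the scatter), the only large change seen. Compound 4 `Cc1c(OCCCCOc2cccc(C(=O)O)c2)ccc(C(=O)CC2CCCC2)c1C` differs from compound 2 by 3-carboxyphenyl in place of 4-carboxyphenyl on an oxygen on a saturated carbon. Among the measured compounds shown here, neither measured step touches the carboxyphenyl part, so no measured step bears on this change; the carboxyphenyl unit is the same in compound 1, compound 2 and compound 3. With nothing to point either way, compound 4 is expected to stay near compound 2, a step of a number 5.8 percentage points higher from compound 2 to compound 4 (within the scatter), estimated at 22% with a range from 6% to 48%.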

Compound 4, largest response reached (reported as percent of maximum), in percent of the reference or control that the assay uses: 22.4%
The estimate for compound 4 lay 0.4 percentage points below the measured number, within the range that was stated.
By their numbers in this assay, from the lowest: compounds 2, 3 and 4 (each within the scatter of the next); then compound 1.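

In this assay, among these compounds, 3-carboxyphenyl in place of 4-carboxyphenyl on this oxygen gives a number 6.2 percentage points higher from compound 2 to compound 4 (within the scatter) and is the first measured change at the carboxyphenyl end. On the core of compound 2, the two placements of the carboxyphenyl group therefore cannot be told apart. No available evidence accounts for this result. As far as these compounds go, whether 3-carboxyphenyl reads the same on the hydroxy-bearing core of compound 1, with its far larger response, stays open. So does the outcome of replacing the carboxylic acid with a tetrazole or an amide.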